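Swapping One Aromatic Group on the Amide

The compounds below may be only part of what the source reports. "The series", "measured", "known", "first", "only" and "open" are said of these compounds alone.

Two related compounds have been measured so far in a functional assay on MCF7 cells (Homo sapiens) for inhibition, read by MTT assay; on this read-out higher numbers stand for weaker inhibition of growth and lower numbers for stronger inhibition of growth. Compound 1 (`CC1=C(/C=C/C(C)=C/C=C/C(C)=C\C(=O)NCc2cccc(F)c2)C(C)(C)CCC1n1ccnc1`) gives 1810 nM, the lower of the two numbers and so the stronger inhibition of growth. Compound 2 (`CC1=C(/C=C/C(C)=C/C=C/C(C)=C\C(=O)NCc2ccc(O)cc2)C(C)(C)CC=C1c1cncnc1`) gives 4960 nM, a gap beyond the usual scatter of repeated measurements. These two compounds differ in more than one place, so their gap cannot be assigned to any single change.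

Compound 3 (`CC1=C(/C=C/C(C)=C/C=C/C(C)=C\C(=O)NCc2ccc(O)cc2)C(C)(C)CCC1n1ccnc1`) keeps the core of compound 1 and alters one group: 4-hydroxyphenyl in place of 3-fluorophenyl on a saturated chain carbon bound to an amide-type nitrogen. Among the measured compounds shown here, no measured pair isolates this swap, so any forecast is uncertain. For the measured compounds named here, the only clue is that compound 2, which also carries 4-hydroxyphenyl, gives 4960 nM. A modest weakening in this assay therefore seems likely, and the expected step is a 1.4-fold higher number from compound 1 to compound 3 (0.16 log units; within the scatter), which may not clearly exceed the scatter. For compound 3 the estimated value is 2600 nM, with an expected range of 1000 nM to 7000 nM.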

Compound 3, concentration for 50% growth inhibition: 160 nM
The estimate for compound 3 lay 16-fold (1.21 log units) above the measured number, and the stated range ends above it.
By their numbers in this assay, from the lowest: compound 3; then compound 1; then compound 2.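

In this assay, this one swap on a saturated chain carbon bound to an amide-type nitrogen gives an 11-fold lower number from compound 1 to compound 3 (1.05 log units; beyond the scatter), with the rest of the molecule left unchanged. Among the compounds shown here, this is the first measured pair that isolates a single change, and it shows that growth inhibition responds strongly to the aromatic group at this position, with 4-hydroxyphenyl giving the stronger inhibition of the two groups compared. The entering group counts one hydrogen-bond donor and one acceptor where the leaving group counts none, but nothing available here connects that difference to the size of the step.

The two groups differ both in the atom they carry and in the number in their names, and this single pair cannot tell which of those differences matters. Going by these compounds, it also remains open whether a plain phenyl group, or an amine or a carboxylic acid in place of the hydroxy group, would keep the stronger inhibition, and whether the same swap would give a similar step on a different core.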